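Methyl on the benzamido ring of compound 2

The source may hold more compounds than are shown below. What is called first, only, known or untested is meant among the compounds shown, and "the series" means these compounds.

In a functional assay on U2OS cells (Homo sapiens) for antiproliferative activity, read by MTT assay, with a stated time of 72 h (a higher number here means a weaker inhibitor, a lower number a stronger inhibitor), compound 1 `O=C(CSc1nc2ccccc2[nH]1)Nc1ccc2nc(NC(=O)c3ccc(C(F)(F)F)cc3)sc2c1` gives 7110 nM and compound 3 `CCn1c(CNc2ccc(OC)cc2)nnc1SCC(=O)Nc1ccc(Cl)cc1` gives 63500 nM. Compound 2 `O=C(CSc1cccc(O)c1)Nc1ccc2nc(NC(=O)c3ccccc3)sc2c1` returns only a limit, > 100000 nM, and so stands at the limit of > 100000 nM in this assay, at which 1 of the 3 values shown sits, without a number of its own. Compound 4 `Cc1ccc(C(=O)Nc2nc3ccc(NC(=O)CSc4cccc(O)c4)cc3s2)cc1` differs from compound 2 in one place: methyl in place of hydrogen on an aromatic carbon. The entering (4-methylphenyl)carbonyl group sits para to the large group. Among the compounds with values here, no measured pair in this set differs in one place, so no step size is known from the data. The step of a number no higher from compound 2 to compound 4 (the limit leaves the size open) is expected to amount to nothing beyond the scatter, most likely with compound 4 again reported only as a limit. Compound 4 is therefore estimated at 100000 nM, with a range from 30000 nM to 300000 nM.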

Compound 4, half-maximal inhibitory concentration: 12400 nM
Compound 4: middle estimate off by 8.1-fold (0.91 log units), on the high side; measured number below the stated range.
By their numbers in this assay, from the lowest: compounds 1 and 4 (each within the scatter of the next); then compound 3. At a limit, above all of these: compound 2.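

In this assay, the benzamido ring accepts a substituent para to a large group, and methyl in place of hydrogen gives an at least 8.0-fold lower number from compound 2 to compound 4 (0.90 log units; beyond the scatter). Within the data shown here, the true size of this step stays unknown, since compound 2 gives only a limit: the limit of > 100000 nM in this assay, at which 1 of the 4 values shown sits. This is the only one-place comparison, and it shows that a single methyl at this position is enough to yield a measurable number.

As far as these compounds go, whether an ethyl group, a methoxy group or a chlorine atom at this position would lower the number further stays open. So does the effect of methyl on another carbon of this ring.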